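An acetyl group on the shared core

A few compounds are considered here, and "the series" means these few. Any claim that something is new, unique, unknown or untested is made for them only; others in the source may bear on it.

Measured in a functional assay on PC-3 cells (Homo sapiens) for antiproliferative activity, read by sulforhodamine B assay, with a stated time of 72 h; on this read-out lower numbers stand for stronger inhibition and higher numbers for weaker inhibition:
compound 1 `COc1ncc(-c2ccc3ncc(NC(=O)C4CCCCC4)c(OC)c3c2)cc1NS(=O)(=O)c1ccc(F)cc1F`: 6630 nM
compound 2 `COc1ncc(-c2ccc3ncc(NCC4CCN(S(C)(=O)=O)CC4)c(OC)c3c2)cc1NS(=O)(=O)c1ccc(F)cc1F`: 2850 nM

Of the two measured compounds, compound 2 has the lower number at 2850 nM. Compound 3 `COc1ncc(-c2ccc3ncc(NC(C)=O)c(OC)c3c2)cc1NS(=O)(=O)c1ccc(F)cc1F` has not yet been measured. It differs from compound 2 as follows: acetyl in place of (1-(methylsulfonyl)piperidin-4-yl)methyl on a nitrogen on an aromatic ring. Among the measured compounds shown here, one measured step bears on this change, at the same place: a 2.3-fold lower number from compound 1 to compound 2 (0.37 log units; beyond the scatter). It is modest. For the measured compounds named here, compound 3 carries acetyl where compound 1 carries cyclohexylcarbonyl, so the higher number of compound 1 at 6630 nM gives the only guide to direction. How acetyl itself behaves in this assay has not been shown. The expected step is small and upward: a 1.4-fold higher number from compound 2 to compound 3 (0.15 log units; within the scatter). For compound 3 the estimated value is 4000 nM, with an expected range from 1300 nM to 12000 nM.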

Compound 3, half-maximal inhibitory concentration: 1240 nM
The estimate for compound 3 lay 3.2-fold (0.51 log units) above the measured number; measured number outside the range, below it.
By their numbers in this assay, from the lowest: compound 3; then compound 2; then compound 1.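

Compound 3 shows that an amide on this nitrogen does not by itself bring a high number in this assay: with a 5.3-fold lower number from compound 1 to compound 3 (0.73 log units; beyond the scatter), methyl in place of cyclohexyl on a carbonyl carbon, the two amides fall on either side of compound 2. The change to acetyl, with its 3 heavy atoms and no ring, also gives a 2.3-fold lower number from compound 2 to compound 3 (0.36 log units; beyond the scatter), so the (1-(methylsulfonyl)piperidin-4-yl)methyl group with its 11 heavy atoms is not the best of these groups at this place. Nothing given here accounts for either step.

Two amides cannot define a trend with the size of the group on the carbonyl carbon, so a propanoyl or a cyclopropylcarbonyl group could fall anywhere along it. From the compounds shown here alone, how the free amine or a methanesulfonamide on this nitrogen would compare with the acetamido group also remains open.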